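The source may hold more compounds than are shown below. What is called first, only, known or untested is meant among the compounds shown, and "the series" means these compounds.

Measured so far:
compound 1 `COc1ccc(-c2cc(-c3ccc(C4NC(=O)c5ccccc5N4)cc3)nc(N)n2)cc1` — an ADME assay on J774.A1 cells (Mus musculus) for cytotoxicity, read by MTT assay, with a stated time of 72 h; a lower number here means that less compound is tolerated, a higher number that more compound is tolerated: 178000 nM
compound 2 `CC(C)c1ccc(C(Nc2ccc(C3(C)NC(=O)c4ccccc4N3)cc2)c2nnnn2C(C)(C)C)cc1` — this assay: > 400000 nM

Among the measured compounds shown here, compound 1 holds the only number of its own in this assay. For compound 2 the value is a limit of the assay rather than a number, namely (the limit of > 400000 nM in this assay, at which 1 of the 2 values shown sits). Compound 3 `COc1cc(-c2cc(-c3ccc(C4NC(=O)c5ccccc5N4)cc3)nc(N)n2)cc(OC)c1OC` is yet to be measured; it differs from compound 1 by 3,4,5-trimethoxyphenyl in place of 4-methoxyphenyl on an aromatic carbon. For the measured compounds named here, no measured pair here differs in a single place, so no measured step guides the expectation. Compound 3 is expected to tolerate somewhat less, a step of a 1.6-fold lower number from compound 1 to compound 3 (0.21 log units; within the scatter) estimated to reach only a little beyond the usual scatter. The estimate for compound 3 is 110000 nM, with a range from 35000 nM to 350000 nM.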

Compound 3, half-maximal cytotoxic concentration: 103000 nM
Beside the measured number, compound 3's estimate is 1.1-fold (0.03 log units) above it, and the stated range covers the measured number.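

Set on the same position of the shared core, 3,4,5-trimethoxyphenyl in place of 4-methoxyphenyl gives in this assay a 1.7-fold lower number from compound 1 to compound 3 (0.24 log units; within the scatter). Among the compounds shown here, this is the first comparison of compounds differing in one place, and it shows that this position accepts the larger trimethoxy-substituted ring with the two values remaining within the scatter of each other. Nothing measured here bears on a cause for this step. As far as these compounds go, whether an amine or a carboxylic acid on this ring would take the number beyond the scatter remains open.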